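The source may report more compounds than this note shows. Statements on the series, on what has been measured and on what is new or still open speak of the compounds shown alone.

Of the compounds shown here, three have so far been measured in a functional assay on U-373MG ATCC cells (Homo sapiens) for inhibition, read by MTT assay, with a stated time of 72 h; a lower number here means a stronger inhibitor, a higher number a weaker inhibitor. Compound 1 `COc1cccc(NC(=S)NC2CC(C)(C)Oc3ccc(Br)cc32)c1` gives 66000 nM, the second highest of the three numbers. Compound 2 `CC1(C)CC(NC(=O)NS(=O)(=O)c2ccccc2)c2cc(Cl)ccc2O1` gives 96000 nM, a value that lies within the usual scatter of compound 1, so the two cannot be told apart. Compound 3 `CC1(C)CC(NC(=S)Nc2cccc([N+](=O)[O-])c2)c2cc(F)ccc2O1` gives 6000 nM, a number far enough below compound 1 to lie beyond the scatter. Compound 4 `CC1(C)CC(NC(=S)Nc2ccc(C#N)cc2)c2cc(Br)ccc2O1` has not yet been measured. It differs from compound 1 in one place: 4-cyanophenyl in place of 3-methoxyphenyl on an amide-type nitrogen. Within the data shown here, no measured pair shows this same change, so the size of the step is open. Compound 4 is expected to give 22000 nM, with a range from 5000 nM to 90000 nM. The expected step of a 3.0-fold lower number from compound 1 to compound 4 (0.48 log units; beyond the scatter) points toward a lower number, of a size that may only just exceed the scatter.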

Compound 4, half-maximal inhibitory concentration: 22000 nM
Beside the measured number, compound 4's estimate shows no gap at the digits printed; measured number inside the range.
By their numbers in this assay, from the lowest: compound 3; then compound 4; then compounds 1 and 2 (each within the scatter of the next).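

Among these compounds, putting 4-cyanophenyl in place of 3-methoxyphenyl on the amide-type nitrogen gives a 3.0-fold lower number from compound 1 to compound 4 (0.48 log units; beyond the scatter) and is the first step here between compounds that differ in one place. It shows that the group at this position can move the number beyond the scatter while the rest of compound 1 stays the same, though the step is modest. Nothing measured here gives a reason for the step. Going by these compounds, it remains open whether the nitrile itself or its place on the ring matters, and how an amine or a carboxylic acid would compare there.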